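Pyrrole diester series: aryl thioester in place of alkyl ester

The compounds below may be only part of what the source reports. "The series", "measured", "known", "first", "only" and "open" are said of these compounds alone.

Measured so far:
compound 1 `Cc1c(C(=O)OC(C)(C)C)c[nH]c1C(=O)OCC1CC1`, 48 nM
compound 2 `Cc1c(C(=O)OC(C)C(C)(C)C)c[nH]c1C(=O)Oc1cccnc1`, 720 nM
compound 3 `CCCOC(=O)c1[nH]c(C)c(C(=O)OC(C)C(C)(C)C)c1C`, 15800 nM

In an assay on CHO cells for inhibition of metabotropic glutamate receptor 1 (Rattus norvegicus) (a lower number here means a stronger inhibitor, a higher number a weaker inhibitor), compound 1 gives 48 nM, the lowest of the three numbers. Compound 2 stands higher, beyond the scatter, and compound 3 higher still, so compound 1 is the strongest inhibitor of the set. No two of the measured compounds differ in one place only, so no single step can be read from them; what the numbers do show is that the one aryl ester, compound 2, sits well above compound 1, though compound 2 also carries a different second ester group.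

Compound 4 `Cc1c(C(=O)OC(C)(C)C)c[nH]c1C(=O)Sc1ccccn1` is not yet measured. It differs from compound 1 by (pyridin-2-yl)sulfanyl in place of cyclopropylmethoxy on a carbonyl carbon. Among the compounds with values here, no measured pair reports this change. A shift toward a higher number is expected, of moderate size, because compound 2 gives 720 nM with an aryl group at the same position. The expected step is a 6.3-fold higher number from compound 1 to compound 4 (0.80 log units; beyond the scatter). For compound 4 in this assay the estimate is 300 nM, within 60 nM to 1500 nM.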

Compound 4, half-maximal inhibitory concentration: 3000 nM
Compound 4: the middle estimate sits 10-fold (1.00 log units) below what was measured, outside the stated range (above it).
By their numbers in this assay, from the lowest: compound 1; then compound 2; then compound 4; then compound 3.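

In this assay, within the data shown here, the first step that changes one place only is large: (pyridin-2-yl)sulfanyl in place of cyclopropylmethoxy on a carbonyl carbon gives a 63-fold higher number from compound 1 to compound 4 (1.80 log units; beyond the scatter). This position therefore does not tolerate every group, since this exchange leaves compound 4 a much weaker inhibitor than compound 1. No measured evidence bears on the reason for the size of this step.

From the compounds shown here alone, the exchange replaces both the oxygen link and the cyclopropylmethyl group, so how the shift divides between the sulfur link and the pyridin-2-yl group remains open. A cyclopropylmethylsulfanyl or a pyridin-2-yloxy group on the same carbonyl carbon would separate the two, and an amide there would test a nitrogen link.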